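Methoxy Addition and Tolerance in Cultured Cells

A few compounds are considered here, and "the series" means these few. Any claim that something is new, unique, unknown or untested is made for them only; others in the source may bear on it.

Measured compounds:
compound 1 `COc1ccc(-c2nc3cc(C(C)O)ccc3[nH]2)cc1` — > 100000 nM
compound 2 `COc1ccc(-c2nc3cc(C(C)O)ccc3[nH]2)c(OC)c1` — > 100000 nM
compound 3 `COc1ccc(-c2nc3cc(/C(C)=N/NC(N)=O)ccc3n2C2CCCCC2)cc1` — "not determined" (no result reported)

In an ADME assay on Vero cells (Chlorocebus sabaeus) for cytotoxicity, read by MTT assay, with a stated time of 96 h (a higher number here means that more compound is tolerated, a lower number that less compound is tolerated), compound 1 gives > 100000 nM, which is a limit of the assay and not a number. In this assay compound 2 gives > 100000 nM, again a limit rather than a number. The change between them is methoxy in place of hydrogen on an aromatic carbon, and the step is a step that the two limits leave unreadable from compound 1 to compound 2. Two of the three values shown sit at the limit of > 100000 nM in this assay, at which 2 of the 3 values shown sit.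

Compound 3 is built on a different core; the difference between the cores of compound 1 and compound 3 is not broken down here. In this assay compound 3 gives "not determined" (no result reported).

Compound 4 `COc1ccc(-c2nc3cc(/C(C)=N/NC(N)=O)ccc3n2C2CCCCC2)c(OC)c1` is not yet measured. It differs from compound 3 by methoxy in place of hydrogen on an aromatic carbon, the same change made from compound 1 to compound 2. Since that earlier step is a step that the two limits leave unreadable from compound 1 to compound 2 and both measured compounds rest at the limit of > 100000 nM in this assay, at which 2 of the 3 values shown sit, the change carries no readable size here, and a value at the limit is expected again. For compound 4 the expected value is 150000 nM, estimated to lie between 50000 nM and 500000 nM.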

Compound 4, half-maximal cytotoxic concentration: 20000 nM
Estimate against measurement, compound 4: 7.5-fold (0.88 log units) above; the measured number lies below the stated range.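

In this assay compound 4 gives 20000 nM and compound 3 gives "not determined" (no result reported), so no step can be read from compound 3 to compound 4. The compounds shown leave open how much of the value of compound 4 comes from the methoxy group and how much from the rest of its structure.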